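Swapping Methyl for Trifluoromethoxy on an Inactive Scaffold

The source may hold more compounds than are shown below. What is called first, only, known or untested is meant among the compounds shown, and "the series" means these compounds.

Measured so far:
compound 1 `Cc1nnsc1CO/N=C/c1c(C)nn(C)c1Oc1ccc(OC(F)(F)F)cc1`: > 50000 nM
compound 2 `CCc1nnsc1CO/N=C/c1c(C)nn(C)c1Oc1ccc(C)cc1`: > 50000 nM

In a functional assay on PANC-1 cells (Homo sapiens) for inhibition, read by MTT assay, with a stated time of 48 h (a higher number here means a weaker inhibitor, a lower number a stronger inhibitor), compound 1 gives > 50000 nM, which is a limit of the assay and not a number. In this assay compound 2 gives > 50000 nM, likewise a limit. Compound 2 therefore stands where every value shown stands: the limit of > 50000 nM in this assay, at which 2 of the 2 values shown sit. Within the data shown here, nothing measured so far separates the two compounds, so no step between them can be read.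

Compound 3 `CCc1nnsc1CO/N=C/c1c(C)nn(C)c1Oc1ccc(OC(F)(F)F)cc1` differs from compound 2 by trifluoromethoxy in place of methyl on an aromatic carbon. Compound 1 carries the same trifluoromethoxy group and still sits at the limit > 50000 nM. With both measured compounds at the limit, no step beyond the usual scatter is expected in this assay, in either direction. Compound 3 is expected to give 80000 nM, with a range from 30000 nM to 300000 nM. The estimated step is a step that the limit leaves unreadable from compound 2 to compound 3, most likely reported again only as a limit.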

Compound 3, half-maximal inhibitory concentration: > 50000 nM
Compound 3: no number, only a limit; the forecaster's own chance of this, stated with the estimate: 85%; the middle value is on the limit's open side.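

Compound 3 also gives only a limit, so no step among compound 1, compound 2 and compound 3 can be read in this assay: the limit of > 50000 nM in this assay, at which 3 of the 3 values shown sit.

These compounds leave open whether trifluoromethoxy in place of methyl changes the value of any compound that gives a measurable number.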